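This account rests on a few compounds, and the source may have more. Where it says the series, first, only, none or still open, it means among the compounds named here.

Of the compounds shown here, three that share one core have been measured in a functional assay on MCF7 cells (Homo sapiens) for inhibition, read by MTT assay; a lower number here means a stronger inhibitor, a higher number a weaker inhibitor. Compound 1 (`CCc1ccc(C(=O)Nc2ccc(Nc3ncnc4cc(OC)c(OC)cc34)cc2)cc1`), with 4-ethylphenyl on a carbonyl carbon, gives 65000 nM. Compound 2 (`COc1cc2ncnc(Nc3ccc(NC(=O)c4ccccc4F)cc3)c2cc1OC`), with 2-fluorophenyl, gives 11000 nM, and compound 3 (`COc1cc2ncnc(Nc3ccc(NC(=O)c4cccc(F)c4)cc3)c2cc1OC`), with 3-fluorophenyl, gives 13600 nM. Compound 3 therefore stands level with the 2-fluorophenyl member, at a 1.2-fold higher number from compound 2 to compound 3 (0.09 log units; within the scatter), and clear of the weakest member, at a 4.8-fold lower number from compound 1 to compound 3 (0.68 log units; beyond the scatter). The step of a 5.9-fold lower number from compound 1 to compound 2 (0.77 log units; beyond the scatter) is of similar, modest size.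

Compound 4 (`COc1cc2ncnc(Nc3ccc(NC(=O)c4ccccc4Cl)cc3)c2cc1OC`) has not yet been measured. It carries 2-chlorophenyl in place of 3-fluorophenyl on a carbonyl carbon. Among the compounds with values here, no compound with chlorine has been measured, so the closest guide is compound 2, which has the same substitution position in its name, and the step of a 1.2-fold higher number from compound 2 to compound 3 (0.09 log units; within the scatter) shows no separation between the two fluorophenyl groups. In this assay no change beyond the scatter is therefore expected, in either direction. The expected step is a 1.1-fold lower number from compound 3 to compound 4 (0.05 log units; within the scatter). For compound 4 the estimated value is 12000 nM, with an expected range from 5500 nM to 28000 nM.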

Compound 4, half-maximal inhibitory concentration: 36000 nM
For compound 4 the middle estimate is 3.0-fold (0.48 log units) below the measured one; measured number outside the range, above it.
By their numbers in this assay, from the lowest: compounds 2 and 3 (each within the scatter of the next); then compounds 4 and 1 (each within the scatter of the next).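

In this assay the position on the carbonyl carbon separates halogens where the two fluorophenyl groups had not separated: chloro in place of fluoro on an aromatic carbon gives a 3.3-fold higher number from compound 2 to compound 4 (0.51 log units; beyond the scatter) and thus a real loss. The change from 3-fluorophenyl to 2-chlorophenyl gives a 2.6-fold higher number from compound 3 to compound 4 (0.42 log units; beyond the scatter) in the same direction, so a halogen on this phenyl ring does not by itself hold the level of compound 2 and compound 3. With a 1.8-fold lower number from compound 1 to compound 4 (0.26 log units; within the scatter) the 2-chlorophenyl member no longer differs from the 4-ethylphenyl member, which had stood apart from both fluorophenyl members.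

From the compounds shown here alone, whether 3-chlorophenyl, or a phenyl ring carrying an amine or a carboxylic acid, would side with the fluorophenyl members remains open. Nothing shown bears on the reason for the separation between chloro and fluoro.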